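A few compounds are considered here, and "the series" means these few. Any claim that something is new, unique, unknown or untested is made for them only; others in the source may bear on it.

Three compounds of one shared core have been followed in an ADME assay, in phosphate buffer, at 28 degrees C, at pH 7.0; a lower number here means that the compound disappears faster, a higher number that the compound lasts longer. Compound 1 `CC(C)(C)C1=C(C(=O)O)N2C(=O)[C@H](CO)[C@H]2O1` gives 5 h. Compound 2 `COC(=O)[C@@H](O)[C@H]1C(=O)N2C(C(=O)O)=C(C(C)(C)C)O[C@H]12` gives 6.2 h, and compound 3 `C[C@H](O)[C@H]1C(=O)N2C(C(=O)O)=C(C(C)(C)C)O[C@H]12` gives 7.1 h. Among the compounds with values here, the three numbers sit within the usual scatter of one another: the step of a 1.2-fold higher number from compound 1 to compound 2 (0.09 log units; within the scatter), the step of a 1.4-fold higher number from compound 1 to compound 3 (0.15 log units; within the scatter) and the step of a 1.1-fold higher number from compound 2 to compound 3 (0.06 log units; within the scatter) are all inside it, so no compound separates itself from the others.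

Compound 4 `C[C@H](F)[C@H]1C(=O)N2C(C(=O)O)=C(C(C)(C)C)O[C@H]12` differs from compound 3 by fluoro in place of hydroxy on a saturated chain carbon bound to a saturated chain carbon and a saturated ring carbon. Within the data shown here, none of the measured steps touches the hydroxy itself; the steps from compound 1 to compound 3 and from compound 2 to compound 3 alter the chain that carries it and stayed within the scatter. With nothing pointing to a change, no step beyond the scatter is expected in this assay, in either direction. The estimated step is a 1.1-fold lower number from compound 3 to compound 4 (0.04 log units; within the scatter). Compound 4 is therefore expected to give about 6.5 h, in the range 3.5 h to 12 h.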

Compound 4, half-life: 7.2 h
Estimate against measurement, compound 4: 1.1-fold (0.04 log units) below; low and high end bracket the measured number.
By their numbers in this assay, from the lowest: compounds 1, 2, 3 and 4 (each within the scatter of the next).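

In this assay, the exchange of hydroxy for fluoro on this saturated chain carbon gives a 1.0-fold higher number from compound 3 to compound 4 (0.01 log units; within the scatter), so the first change shown at the hydroxy itself, which also removes its hydrogen-bond donor, leaves the half-life within the scatter. The 1-fluoroethyl group does not separate from the other two chains either, with a 1.2-fold higher number from compound 2 to compound 4 (0.06 log units; within the scatter) and a 1.4-fold higher number from compound 1 to compound 4 (0.16 log units; within the scatter). Nothing available here explains why the number holds across this exchange.

On these data alone, whether an amine, a carboxylic acid or a longer chain on this carbon would give a step beyond the scatter remains open. As far as these compounds go, all four compounds share one core, so it is also open whether any group at this position can move the half-life in this assay at all.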